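Three Values at the Assay Limit and a Fourth Compound

A few compounds are considered here, and "the series" means these few. Any claim that something is new, unique, unknown or untested is made for them only; others in the source may bear on it.

Compound 1 `COc1cccc(/C=C/C(=O)c2sc(Nc3ccccc3)nc2C)c1`, compound 2 `Cc1ccccc1Nc1nc(C)c(C(=O)/C=C/c2ccc(Cl)cc2)s1` and compound 3 `Cc1ccccc1Nc1nc(C)c(C(=O)/C=C/c2ccccc2)s1` share one core and differ only in the aromatic groups at its two ends. In a functional assay on Bel-7402 cells (Homo sapiens) for cytotoxicity, read by MTT assay (on this read-out higher numbers stand for weaker inhibition and lower numbers for stronger inhibition), compound 1 gives > 25000 nM, which is a limit of the assay and not a number. In this assay compound 2 gives > 25000 nM, again a limit. In this assay compound 3 gives > 25000 nM, likewise a limit. The step that the two limits leave unreadable from compound 2 to compound 3 cannot be sized because of the limit of > 25000 nM in this assay, at which 3 of the 3 values shown sit. Among the measured compounds shown here, compound 2 therefore stands at the limit, as do both other values shown, and no compound can be ranked against another.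

Compound 4 `Cc1nc(Nc2ccc(Cl)c(Cl)c2)sc1C(=O)/C=C/c1ccc(Cl)cc1` differs from compound 2 by 3,4-dichlorophenyl in place of 2-methylphenyl on a nitrogen on an aromatic ring. For the measured compounds named here, no measured step touches the group on that nitrogen, and the one measured step, which changes the other aromatic group, is unreadable. One therefore expects no movement in this assay that could be read, and estimates for compound 4 a value of 30000 nM, within the range 8000 nM to 100000 nM. The expected step that the limit leaves unreadable from compound 2 to compound 4 is accordingly estimated as small, with the result most likely reported again as a limit.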

Compound 4, half-maximal inhibitory concentration: > 25000 nM
Compound 4 gave a limit, no number; the forecaster's own chance of this, stated with the estimate: 70%; the middle value is on the limit's open side.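

In this assay compound 4 stands at a limit, as compound 2 does, and no new step can be read between them: the limit of > 25000 nM in this assay, at which 4 of the 4 values shown sit.

The compounds shown leave open whether any other aromatic group at either end of the shared core would give a readable value in this assay.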